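Formyl in Place of the Azo Arm on the Triazole Scaffold

A few compounds are considered here, and "the series" means these few. Any claim that something is new, unique, unknown or untested is made for them only; others in the source may bear on it.

Compound 1 `COc1cc(/C=C/C(C)=O)ccc1OCc1cn(-c2ccc(/N=N/c3ccccc3)cc2)nn1` gives 75900 nM in a functional assay on MCF7 cells (Homo sapiens) for antiproliferative activity, read by MTT assay, with a stated time of 48 h; a lower number here means a stronger inhibitor, a higher number a weaker inhibitor.
Compound 2 `COc1cc(/C=C/C(C)=O)ccc1OCc1cn(-c2c(Cl)cccc2Cl)nn1` gives 26600 nM.
Compound 3 `COc1cc(/C=C/C(C)=O)ccc1OCc1cn(-c2ccc([N+](=O)[O-])cc2)nn1` gives > 100000 nM, which is a limit of this assay and not a number.

Of the two numbers, compound 1 stands highest; compound 2, its nearest neighbour, sits a clear step below it. The untested compound 4 `COc1cc(/C=C/C(C)=O)ccc1OCc1cn(-c2ccc(C=O)cc2)nn1` differs from compound 1 by a group of 2 heavy atoms (1 carbon, 1 oxygen; no ring) in place of a group of 8 heavy atoms (6 carbon, 2 nitrogen; one six-membered aromatic ring of carbon only), on an aromatic carbon. For the measured compounds named here, the one measured step that bears on this, an at least 1.3-fold higher number from compound 1 to compound 3 (0.11 log units; that floor lies within the scatter), exchanged the same departing group for another small one and ran into the limit (the limit of > 100000 nM in this assay, at which 1 of the 3 values shown sits). As the change to compound 4 is of the same kind, its number is expected to sit near compound 1 or somewhat higher, with a fair chance that this assay again reports only its limit. Compound 4 is therefore estimated at 90000 nM (range 40000 nM to 200000 nM), which means a 1.2-fold higher number from compound 1 to compound 4 (0.07 log units; within the scatter).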

Compound 4, half-maximal inhibitory concentration: 86400 nM
The estimate for compound 4 lay 1.0-fold (0.02 log units) above the measured number; low and high end bracket the measured number.
By their numbers in this assay, from the lowest: compound 2; then compounds 1 and 4 (each within the scatter of the next). At a limit, above all of these: compound 3.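

In this assay, formyl can stand in for the much larger group of compound 1 without a readable difference, a 1.1-fold higher number from compound 1 to compound 4 (0.06 log units; within the scatter), so the number at this position does not follow the size of that group across these two compounds. The small formyl does not match the 2,6-dichlorophenyl compound, a 3.2-fold higher number from compound 2 to compound 4 (0.51 log units; beyond the scatter). Compound 3 remains a limit and not a number, which leaves only a floor, an at least 1.1-fold lower number from compound 3 to compound 4 (0.06 log units; that floor lies within the scatter), and no order against formyl: the limit of > 100000 nM in this assay, at which 1 of the 4 values shown sits.

Going by these compounds, whether an amine or a carboxylic acid at this position would reach the level of compound 2 stays open.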